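A few compounds are considered here, and "the series" means these few. Any claim that something is new, unique, unknown or untested is made for them only; others in the source may bear on it.

Measured compounds:

Compound 1, `COc1ccc(S(=O)(=O)c2cn(-c3ccc4c(c3)B(O)OC4)c3ccccc23)cc1`. In an ADME assay on L929 cells (Mus musculus) for cytotoxicity, read by resazurin assay, with a stated time of 72 h (on this read-out higher numbers stand for weaker inhibition and lower numbers for stronger inhibition), compound 1 gives > 10 ug/mL, which is a limit of the assay rather than a number.
Compound 2, `OB1OCc2ccc(-n3cccc3Sc3ccccc3Cl)cc21`. In this assay compound 2 gives > 10 ug/mL, again a limit of the assay.
Compound 3, `CC(=O)c1ccn(-c2ccc3c(c2)B(O)OC3)c1`. In this assay compound 3 gives > 10 ug/mL, also a limit of the assay.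

Among the compounds with values here, compound 3 therefore stands where every measured compound stands: at the limit of > 10 ug/mL in this assay, at which 3 of the 3 values shown sit, so no number separates it from the others, and no measured step can be drawn between any two of them.

Compound 4, `O=C(c1ccc(O)cc1)c1ccn(-c2ccc3c(c2)B(O)OC3)c1`, is not yet measured. It differs from compound 3 in one place: 4-hydroxyphenyl in place of methyl on a carbonyl carbon. With nothing but limits to build on, no step beyond the usual scatter is expected from compound 3 to compound 4 in this assay, so the expected step is a step that the limit leaves unreadable from compound 3 to compound 4. Compound 4 is expected to give about 15 ug/mL, in a range from 7 ug/mL to 40 ug/mL, most likely reported again as a limit.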

Compound 4, half-maximal inhibitory concentration: > 10 ug/mL
Compound 4: no number, only a limit; the forecaster's own chance of this, stated with the estimate: 75%; the middle value does not contradict the limit.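

Compound 3 and compound 4 both give a limit of the assay rather than a number, so no step can be read between them: the limit of > 10 ug/mL in this assay, at which 4 of the 4 values shown sit.

The compounds shown leave open which change in structure, if any, would bring a readable number in this assay.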